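Benzyl thioether series: chloro to trifluoromethyl step

This account rests on a few compounds, and the source may have more. Where it says the series, first, only, none or still open, it means among the compounds named here.

The three measured compounds share one core and differ in the benzyl carried on the sulfur. Compound 1 `Cc1cccc(CSc2cc(Cl)c(C)cc2S(=O)(=O)/N=C(\N)n2nccc2-c2ccccc2)c1` in an ADME assay on microsomes from liver (Homo sapiens) for metabolic stability, read by LC-MS, using NADPH, tested at 5 uM (a higher number here means that the compound lasts longer, a lower number that the compound disappears faster), gives 0.232 h. Compound 2 `Cc1cc(S(=O)(=O)/N=C(\N)n2nccc2-c2ccccc2)c(SCc2cccc(C(F)(F)F)c2)cc1Cl` gives 0.0863 h. Compound 3 `Cc1cc(S(=O)(=O)/N=C(\N)n2nccc2-c2ccccc2)c(SCc2ccccc2Cl)cc1Cl` gives 0.226 h; on these numbers compound 3 stands second highest of the three, its nearest neighbour being compound 1, within the scatter, and its furthest compound 2, beyond it. The step of a 1.0-fold lower number from compound 1 to compound 3 (0.01 log units; within the scatter) is within the scatter, whereas a 2.7-fold lower number from compound 1 to compound 2 (0.43 log units; beyond the scatter) and a 2.6-fold higher number from compound 2 to compound 3 (0.42 log units; beyond the scatter) are both beyond it and modest in size.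

Compound 4 `Cc1cc(S(=O)(=O)/N=C(\N)n2nccc2-c2ccccc2)c(SCc2ccccc2C(F)(F)F)cc1Cl` is not yet measured. It differs from compound 3 in one place: trifluoromethyl in place of chloro on an aromatic carbon. Among the measured compounds shown here, no measured step exchanges chloro for trifluoromethyl. The closest measured step is a 2.7-fold lower number from compound 1 to compound 2 (0.43 log units; beyond the scatter), which also brings in trifluoromethyl on an aromatic carbon, though the group it replaces there is methyl rather than chloro. The other two steps swap whole benzyl groups and do not isolate this change. On that basis a modest downward step is expected, a 1.9-fold lower number from compound 3 to compound 4 (0.27 log units; within the scatter). For compound 4 the estimate in this assay is 0.12 h, with a range from 0.06 h to 0.25 h.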

Compound 4, half-life: 0.15 h
The estimate for compound 4 lay 1.3-fold (0.10 log units) below the measured number; measured number inside the range.
By their numbers in this assay, from the lowest: compounds 2, 4, 3 and 1 (each within the scatter of the next, the first and the last beyond it).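

Working notes on the 2-substituted benzyl position. In this assay, among the compounds shown here, a 1.5-fold lower number from compound 3 to compound 4 (0.18 log units; within the scatter) gives the first direct reading of trifluoromethyl in place of chloro on this aromatic carbon, ortho to a large group, and it stays within the scatter, whereas the trifluoromethyl-for-methyl exchange on a different aromatic carbon, a 2.7-fold lower number from compound 1 to compound 2 (0.43 log units; beyond the scatter), lies beyond it. The exchange of 3-(trifluoromethyl)phenyl for 2-(trifluoromethyl)phenyl, a 1.7-fold higher number from compound 2 to compound 4 (0.24 log units; within the scatter), and of 3-methylphenyl for 2-(trifluoromethyl)phenyl, a 1.5-fold lower number from compound 1 to compound 4 (0.19 log units; within the scatter), are also within the scatter, so compound 4 cannot be separated from any of the other three compounds, even though compound 2 remains separated from compound 1 and compound 3. Nothing available bears on what underlies these readings.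

Still open, from the compounds shown here alone, is whether this aromatic carbon tolerates a wider range of groups in this assay, for example a methoxy, a nitrile, an amine or a carboxylic acid in place of chloro or trifluoromethyl. Also open, going by these compounds, is whether the 2-(trifluoromethyl)phenyl result would hold with a longer chain between the sulfur and the ring.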